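Swapping a Pyridine for a Thiophene on a Pyridine Core

A few compounds are considered here, and "the series" means these few. Any claim that something is new, unique, unknown or untested is made for them only; others in the source may bear on it.

Two close relatives of the shared core have been measured. In a functional assay on DU-145 cells (Homo sapiens) for cytotoxicity, read by CCK-8 assay and cell counting, with a stated time of 2 days (on this read-out lower numbers stand for stronger inhibition and higher numbers for weaker inhibition), compound 1 `Oc1ccc(-c2cc(-c3cccs3)nc(-c3ccccc3Cl)c2)cc1` gives 4190 nM, and compound 2 `Oc1cccc(-c2cc(-c3ccc(Cl)cc3)nc(-c3cccs3)c2)c1` gives 11600 nM in this assay. For compound 3 `Oc1cccc(-c2cc(-c3cccnc3)nc(-c3ccccc3Cl)c2)c1` the entry in this assay reads "not determined" (no result reported), so it stands nowhere on the scale shown here. Compound 4 `Oc1cccc(-c2cc(-c3cccs3)nc(-c3ccccc3Cl)c2)c1` differs from compound 3 in one place: thiophen-2-yl in place of pyridin-3-yl on an aromatic carbon. Going by the values given here, with no measured step for this pair, the size and direction of any change cannot be read from the data, and a shift no larger than the usual scatter would be unsurprising. Compound 4 is expected to give roughly 6000 nM in this assay, within a range from 2000 nM to 20000 nM.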

Compound 4, half-maximal inhibitory concentration: 1700 nM
Estimate against measurement, compound 4: 3.5-fold (0.55 log units) above, outside the stated range (below it).
By their numbers in this assay, from the lowest: compound 4; then compound 1; then compound 2.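

In this assay compound 4 has the lowest number of the three compounds with a result, so a thiophen-2-yl group at this position is compatible with the strongest inhibition seen here. Placing 3-hydroxyphenyl in place of 4-hydroxyphenyl gives a 2.5-fold lower number from compound 1 to compound 4 (0.39 log units; beyond the scatter) and placing 2-chlorophenyl in place of 4-chlorophenyl gives a 6.8-fold lower number from compound 2 to compound 4 (0.83 log units; beyond the scatter), showing that the groups elsewhere on the core also shift the number. The step from pyridin-3-yl to thiophen-2-yl itself cannot be read, since compound 3 has no result.

No measured evidence explains these steps. Going by these compounds, how a furan-2-yl ring or an amine would behave at this position remains open.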